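Furan to thiophene swap on the benzylic ether arm

A few compounds are considered here, and "the series" means these few. Any claim that something is new, unique, unknown or untested is made for them only; others in the source may bear on it.

Compound 2 `CN1CCN(CCCCOc2c(OCc3ccco3)cc(O)c3c(=O)cc(-c4ccccc4)oc23)CC1` is the starting point of this step. In a functional assay on HepG2 cells (Homo sapiens) for cytotoxicity, read by MTT assay, with a stated time of 72 h (on this read-out higher numbers stand for weaker inhibition and lower numbers for stronger inhibition), compound 2 gives 4110 nM. Going by the values given here, the only other measured member, compound 1 `Cc1ccc(COc2cc(O)c3c(=O)cc(-c4ccccc4)oc3c2OCCCCN2CCN(C)CC2)cc1`, gives in this assay 5090 nM. Among the compounds with values here, the single measured step, a 1.2-fold lower number from compound 1 to compound 2 (0.09 log units; within the scatter), exchanges the aryl group on the same saturated chain carbon bound to an oxygen on the aromatic ring, and its size lies within the scatter. Compound 2 and compound 1 therefore sit within the scatter of each other; no ordering between the two can be read from the numbers shown.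

Compound 3 `CN1CCN(CCCCOc2c(OCc3cccs3)cc(O)c3c(=O)cc(-c4ccccc4)oc23)CC1` is not yet measured. The change is thiophen-2-yl in place of furan-2-yl on a saturated chain carbon bound to an oxygen on an aromatic ring. Within the data shown here, the one step that bears on it, a 1.2-fold lower number from compound 1 to compound 2 (0.09 log units; within the scatter), is an exchange of the aryl group at the same place, and it moved the number by less than the scatter. On that basis no step beyond the scatter is expected for compound 3, and its expected step is a 1.0-fold lower number from compound 2 to compound 3 (0.01 log units; within the scatter). The estimate for compound 3 in this assay is 4000 nM, within a range of 1800 nM to 9000 nM.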

Compound 3, half-maximal inhibitory concentration: 4560 nM
Beside the measured number, compound 3's estimate is 1.1-fold (0.06 log units) below it, within the range that was stated.
By their numbers in this assay, from the lowest: compounds 2, 3 and 1 (each within the scatter of the next).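

In this assay, going by these compounds alone, replacing furan-2-yl with thiophen-2-yl on a saturated chain carbon bound to an oxygen on an aromatic ring gives a 1.1-fold higher number from compound 2 to compound 3 (0.05 log units; within the scatter) and is the first exchange here of one five-membered aromatic ring for another, with sulfur in place of oxygen as the hetero atom. Thiophen-2-yl in place of 4-methylphenyl at the same place gives a 1.1-fold lower number from compound 1 to compound 3 (0.05 log units; within the scatter) in the same read-out, so the three aryl groups now shown at this place, furan-2-yl, thiophen-2-yl and 4-methylphenyl, cannot be told apart on these numbers, and no compound shown goes against this. No independent data bear on why these exchanges leave the numbers within the scatter.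

Still open, as far as these compounds go, is whether a non-aromatic or charged group at this place, such as a primary amine or a carboxylic acid on the aryl ring, or a longer chain such as 2-(thiophen-2-yl)ethyl in place of (thiophen-2-yl)methyl, would produce a step beyond the scatter. The compounds shown also leave open whether the same three aryl groups would remain indistinguishable in any other cell line.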